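This account rests on a few compounds, and the source may have more. Where it says the series, first, only, none or still open, it means among the compounds named here.

Measured in a functional assay on Rec1 cells (Homo sapiens) for inhibition, read by luminescence and CellTiter-Glo, with a stated time of 72 h; on this read-out higher numbers stand for weaker inhibition and lower numbers for stronger inhibition:
- compound 1 `C/C=C/C(=O)Nc1cccc(Cn2nc(-c3ccc(Oc4ccccc4)cc3)cc2C(=O)O)c1`: 26000 nM
- compound 2 `CCOC(=O)c1cc(-c2ccc(Oc3ccccc3)cc2)nn1Cc1cccc(NC(=O)CCl)c1`: 400 nM

Compound 1 stands at the highest of the two numbers, and the gap down to compound 2 lies beyond the scatter. Compound 3 `C/C=C/C(=O)Nc1cccc(Cn2nc(-c3ccc(Oc4ccccc4)cc3)cc2CO)c1` keeps the core of compound 1 with one change: hydroxymethyl in place of carboxy on an aromatic carbon. For the measured compounds named here, no measured pair isolates this place. A step to a lower number in this assay, beyond the scatter, is expected, resting only on compound 1 standing at 26000 nM, the top of the measured range. The expected change is a 6.5-fold lower number from compound 1 to compound 3 (0.81 log units; beyond the scatter). The estimate for compound 3 is 4000 nM, with an expected range of 1000 nM to 15000 nM.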

Compound 3, half-maximal inhibitory concentration: 3400 nM
Beside the measured number, compound 3's estimate is 1.2-fold (0.07 log units) above it; the measured number falls inside the stated range.
By their numbers in this assay, from the lowest: compound 2; then compound 3; then compound 1.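

This position, on an aromatic carbon next to the ring nitrogen, now has its first single-place comparison: in this assay, hydroxymethyl in place of carboxy gives a 7.6-fold lower number from compound 1 to compound 3 (0.88 log units; beyond the scatter) and so shows that the number responds to this change. The count of hydrogen-bond donors and acceptors is the same for both groups, and neither carries a net charge, so these counts do not separate them. No measurement shown accounts for the step. From the compounds shown here alone, whether an amine or a primary amide at this position would move the number further remains open.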